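The source may hold more compounds than are shown below. What is called first, only, known or untested is meant among the compounds shown, and "the series" means these compounds.

Compound 1 `CC(=O)OCCOCN1c2ccccc2C(=O)NS1(=O)=O`. In a functional assay on HEL cells (Homo sapiens) (on this read-out lower numbers stand for higher toxicity in this test and higher numbers for lower toxicity in this test), compound 1 gives > 200 ug/mL, which is a limit of the assay.
Compound 2 `CCCOCN1c2ccccc2C(=O)NS1(=O)=O`. In this assay compound 2 gives > 50 ug/mL, also a limit.
Compound 3 `CC(=O)OCCOCN1C(=O)c2ccccc2NS1(=O)=O`. In this assay compound 3 gives > 200 ug/mL, again a limit.

Within the data shown here, compound 1 therefore stands only at a limit, (the limit of > 200 ug/mL in this assay, at which 2 of the 3 values shown sit), and nothing in this assay sets it apart from the others; the sole step, a step that the two limits leave unreadable from compound 1 to compound 2, is blocked by the limit of > 50 ug/mL in this assay, at which 1 of the 3 values shown sits. Compound 4 `CC(=O)OCCOCN1c2ccccc2C(=O)N(Cc2ccccc2)S1(=O)=O` carries benzyl in place of hydrogen on an amide-type nitrogen in a ring. Among the measured compounds shown here, no measured step bears readably on this change. The expected step of a number no higher from compound 1 to compound 4 (the limit leaves the size open) is none beyond the scatter. Compound 4 is estimated at 200 ug/mL, between 60 ug/mL and 400 ug/mL, most likely reported again as a limit.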

Compound 4, half-maximal cytotoxic concentration: 100 ug/mL
The estimate for compound 4 lay 2.0-fold (0.30 log units) above the measured number; low and high end bracket the measured number.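

Benzyl on the amide-type nitrogen in a ring gives the first value in this assay that is a number and not a limit: compound 4 gives 100 ug/mL. The change reads as an at least 2.0-fold lower number from compound 1 to compound 4 (0.30 log units; that floor lies within the scatter). Its true size stays open, for compound 1 stands only at a limit: the limit of > 200 ug/mL in this assay, at which 2 of the 4 values shown sit.

The compounds shown leave open whether a methyl group, an amine-bearing chain or a carboxylic acid on this nitrogen would also give a number and not a limit. As far as these compounds go, whether benzyl acts alike on the core of compound 3 also remains open.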